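A Triazole Aryl Swap on a Free Phenol Core

The source may hold more compounds than are shown below. What is called first, only, known or untested is meant among the compounds shown, and "the series" means these compounds.

compound 1 `C=C1C(=O)[C@]23C[C@@]1(O)CC[C@H]2c1ccc(OS(=O)(=O)c2ccc(C)cc2)c(C)c1[C@@H]3Cn1cc(-c2ccccn2)nn1`: 2310 nM
compound 2 `Cc1ccc(S(=O)(=O)Oc2ccc3c(c2C)[C@H](Cn2cc(-c4ccc(Cl)cc4)nn2)[C@@]24CC(=O)[C@@](C)(CC[C@@H]32)C4)cc1`: a limit of > 20000 nM
compound 3 `C=C1C(=O)[C@]23C[C@@]1(O)CC[C@H]2c1ccc(O)c(C)c1[C@@H]3Cn1cc(-c2ccccn2)nn1`: 1570 nM

In a functional assay on A549 cells (Homo sapiens) for cytotoxicity, read by MTT assay, with a stated time of 4 days (a lower number here means a stronger inhibitor, a higher number a weaker inhibitor), compound 3 gives 1570 nM, the lowest of the two numbers, with compound 1 nearest at 2310 nM. For compound 2 this assay reports only a limit, > 20000 nM. Among the compounds with values here, the single measured step, a 1.5-fold lower number from compound 1 to compound 3 (0.17 log units; within the scatter), concerns the phenolic oxygen and not the triazole substituent. Compound 4 `C=C1C(=O)[C@]23C[C@@]1(O)CC[C@H]2c1ccc(O)c(C)c1[C@@H]3Cn1cc(-c2ccc(Cl)cc2)nn1` differs from compound 3 by 4-chlorophenyl in place of pyridin-2-yl on an aromatic carbon. Within the data shown here, no measured step bears on this swap; compound 2 carries the same 4-chlorophenyl but on a different core, so its value cannot be read as a step. Compound 4 is therefore expected near compound 3, estimated at 3000 nM (range 1000 nM to 15000 nM), a step of a 1.9-fold higher number from compound 3 to compound 4 (0.28 log units; within the scatter).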

Compound 4, half-maximal inhibitory concentration: 640 nM
Compound 4: the middle estimate sits 4.7-fold (0.67 log units) above what was measured, and the stated range ends above it.
By their numbers in this assay, from the lowest: compound 4; then compounds 3 and 1 (each within the scatter of the next). At a limit, above all of these: compound 2.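

In this assay, the aryl group on the triazole turns out to matter: a 2.5-fold lower number from compound 3 to compound 4 (0.39 log units; beyond the scatter), whereas the earlier change on the phenolic oxygen stayed within the scatter. Within the data shown here, the step is modest, but it is the first in this set to show that the shared core responds to a change at this position. The values shown give no cause for the change.

Going by these compounds, it remains open whether the ring nitrogen leaving or the chlorine entering accounts for the step. On these data alone, whether plain phenyl, or a phenyl bearing an amine, would read closer to compound 3 or compound 4 also remains open.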